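Benzyl in Place of Dimethylphenyl on the Amide Nitrogen

A few compounds are considered here, and "the series" means these few. Any claim that something is new, unique, unknown or untested is made for them only; others in the source may bear on it.

Compound 2 `COc1ccc2c(=O)c(/C=C/C(=O)Nc3cc(C)ccc3C)coc2c1` gives in a functional assay (QGY7701 cells, Homo sapiens) for inhibition, read by MTT assay, with a stated time of 48 h (a higher number here means a weaker inhibitor, a lower number a stronger inhibitor), only a limit, reported as > 100000 nM, so no number is known for it. Compound 1 `O=C(/C=C/c1coc2cc(O)ccc2c1=O)NCc1ccc(F)cc1` likewise gives only a limit in this assay, > 100000 nM. Within the data shown here, compound 3 `Cc1ccccc1NC(=O)/C=C/c1coc2cc(O)ccc2c1=O` is the one compound with a measured number in this assay, 9320 nM. Among the measured compounds shown here, the only step between measured compounds that differ in one place is an at least 10-fold lower number from compound 1 to compound 3 (1.03 log units; beyond the scatter), which means that a 2-methylphenyl in place of a 4-fluorobenzyl on the amide nitrogen turned a compound at the limit into a measurable inhibitor; the comparison rests on (the limit of > 100000 nM in this assay, at which 2 of the 3 values shown sit).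

Compound 4 `COc1ccc2c(=O)c(/C=C/C(=O)NCc3ccccc3)coc2c1`, not yet measured, differs from compound 2 as follows: benzyl in place of 2,5-dimethylphenyl on an amide-type nitrogen. This runs in the opposite sense to the measured step, since here a benzyl enters where a ring attached directly to the nitrogen leaves. Because an at least 10-fold lower number from compound 1 to compound 3 (1.03 log units; beyond the scatter) favoured the directly attached ring, no gain is expected here, and compound 2 already sits at the limit. Compound 4 is therefore expected to stay at or beyond that limit, estimated at 150000 nM with a range from 50000 nM to 500000 nM. The expected step that the limit leaves unreadable from compound 2 to compound 4 is, in effect, none beyond the scatter.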

Compound 4, half-maximal inhibitory concentration: > 100000 nM
Compound 4: no number, only a limit; the forecaster's own chance of this, stated with the estimate: 85%; the middle value is on the limit's open side.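

Compound 2 and compound 4 both give only a limit, so no step between them can be read, and the swap of 2,5-dimethylphenyl for benzyl shows no readable change: the limit of > 100000 nM in this assay, at which 3 of the 4 values shown sit.

The compounds shown leave open whether benzyl or 2,5-dimethylphenyl on the amide-type nitrogen gives the stronger inhibitor, and how far past the limit either compound lies.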